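The source may report more compounds than this note shows. Statements on the series, on what has been measured and on what is new or still open speak of the compounds shown alone.

The study concerns a shared core carried by compound 1 `O=C1COc2ccc(-c3cnc(Cl)c(NS(=O)(=O)c4ccc(F)cc4)c3)cc2N1c1ccc(F)cc1`, compound 2 `COc1ccc(N2C(=O)COc3ccc(-c4ccc(O)cc4)cc32)cc1` and compound 3 `COc1ncc(-c2ccc3c(c2)N(c2ccc(F)cc2)C(=O)CO3)cc1NS(=O)(=O)c1ccc(F)cc1`, all tested in a functional assay on A-375 cells (Homo sapiens) for antiproliferative activity, read by MTT assay, with a stated time of 72 h; a higher number here means a weaker inhibitor, a lower number a stronger inhibitor. In this assay compound 1 reaches only the limit of the assay, > 40000 nM. Compound 2 likewise gives only a limit, > 40000 nM. Compound 3 too gives only a limit, > 40000 nM. Compound 3 therefore stands where every measured compound stands, at the limit of > 40000 nM in this assay, at which 3 of the 3 values shown sit. Going by the values given here, the one change between measured compounds is a step that the two limits leave unreadable from compound 1 to compound 3, and it yields no readable size. The next compound, compound 4 `COc1ncc(-c2ccc3c(c2)N(C2CCCCC2)C(=O)CO3)cc1NS(=O)(=O)c1ccc(F)cc1`, differs from compound 3 by cyclohexyl in place of 4-fluorophenyl on an amide-type nitrogen in a ring. Among the compounds with values here, no measured step touches this position, and none of the three values is a number, so there is nothing from which to read a size or a direction for this change. With compound 3 at the limit, the expectation for compound 4 is that it likewise reaches only the limit, so an expected shift of a step that the limit leaves unreadable from compound 3 to compound 4 is essentially none. Compound 4 is accordingly estimated at 60000 nM, with a range from 20000 nM to 200000 nM.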

Compound 4, half-maximal inhibitory concentration: > 40000 nM
Compound 4: a limit, no number (the forecaster's own chance of this, stated with the estimate: 85%); the middle value is on the limit's open side.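

In this assay compound 4 gives only a limit, > 40000 nM, so the change from compound 3 to compound 4 cannot be read as a step. The compounds shown leave open which change on the shared core would give a readable value: the limit of > 40000 nM in this assay, at which 4 of the 4 values shown sit.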